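Bromo on the sulfanyl phenyl: expected effect on cytotoxicity

The source may hold more compounds than are shown below. What is called first, only, known or untested is meant among the compounds shown, and "the series" means these compounds.

Measured compounds:
Compound 1, `CC(O)(CSc1ccccc1)c1nc(-c2ccccc2)no1` — in a functional assay on DU-145 cells (Homo sapiens) for cytotoxicity, read by MTT assay (on this read-out higher numbers stand for weaker inhibition and lower numbers for stronger inhibition), compound 1 gives > 100000 nM, which is a limit of the assay and not a number.
Compound 2, `CC(O)(CSc1ccccc1)c1nc(-c2ccc(F)c(Cl)c2)no1` — in this assay compound 2 gives 5500 nM.
Compound 3, `CC(O)(CS(=O)(=O)c1ccc(F)cc1)c1nc(-c2ccc(Cl)cc2)no1` — in this assay compound 3 gives > 100000 nM, again a limit of the assay and not a number.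

Among the compounds with values here, compound 2 therefore stands alone: it is the only compound with a number, the other two values being limits, as the limit of > 100000 nM in this assay, at which 2 of the 3 values shown sit, records. Within the data shown here, the single measured step, an at least 18-fold lower number from compound 1 to compound 2 (1.25 log units; beyond the scatter), concerns the aryl group attached to the shared core, not the sulfanyl side of the molecule.

Compound 4, `CC(O)(CSc1ccc(Br)cc1)c1nc(-c2ccc(F)c(Cl)c2)no1`, differs from compound 2 by bromo in place of hydrogen on an aromatic carbon. Among the measured compounds shown here, no measured step touches the phenylsulfanyl group; compound 3 differs from compound 2 in more than one place, so its result cannot be read against this single change. There is thus no evidence for a step beyond the scatter in this assay in either direction.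

Compound 4 is expected to give roughly 4500 nM, between 1500 nM and 15000 nM. The expected step is a 1.2-fold lower number from compound 2 to compound 4 (0.09 log units; within the scatter), within the scatter.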

Compound 4, half-maximal inhibitory concentration: 8800 nM
Compound 4: middle estimate off by 2.0-fold (0.29 log units), on the low side; measured number inside the range.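

In this assay, the first change measured on the phenylsulfanyl group is small: a 1.6-fold higher number from compound 2 to compound 4 (0.20 log units; within the scatter). Phenylsulfanyl and (4-bromophenyl)sulfanyl therefore cannot be told apart on this read-out when the 3-chloro-4-fluorophenyl group is present, and the aromatic carbon para to a large group accepts a bromo without loss of a measurable number. This contrasts with the earlier step on the other aryl group, an at least 18-fold lower number from compound 1 to compound 2 (1.25 log units; beyond the scatter), so in the compounds shown the large change belongs to that aryl group and not to this position; any other comparison with compound 1 or compound 3 cannot be read, and only compound 2 and compound 4 carry numbers: the limit of > 100000 nM in this assay, at which 2 of the 4 values shown sit.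

A single bromo says little about the position as a whole, so an amine, a carboxylic acid or a methoxy group at the same aromatic carbon remains an open test of how much change it accepts. Also open, from the compounds shown here alone, is whether bromo behaves the same way with an unsubstituted phenyl on the other side of the core, and what a sulfonyl link does on its own in place of the sulfanyl link.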